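Working notes: from compound 2 to compound 3

The source may hold more compounds than are shown below. What is called first, only, known or untested is meant among the compounds shown, and "the series" means these compounds.

Measured so far in a functional assay on L5178Y cells (Mus musculus) for inhibition, read by MTT assay, with a stated time of 24 h; a lower number here means a stronger inhibitor, a higher number a weaker inhibitor:
- compound 1 `COc1cc(O)c2c(c1)O[C@H](c1ccc(O)cc1)C/C2=N\Nc1ccc(Br)cn1`: 4300 nM
- compound 2 `COc1ccc([C@@H]2C/C(=N\N)c3c(O)cc(OC)cc3O2)cc1`: >= 11300 nM (a limit)

Compound 2 stands at the limit of >= 11300 nM in this assay, at which 1 of the 2 values shown sits. Its reading is a limit and not a number, so any step that starts from compound 2 can be sized only loosely.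

Compound 3 `COc1ccc([C@@H]2C/C(=N\Nc3ccc(Br)cn3)c3c(O)cc(OC)cc3O2)cc1` has not yet been measured. It carries 5-bromopyridin-2-yl in place of hydrogen on the amine nitrogen of compound 2: 5-bromopyridin-2-yl in place of hydrogen on an amine nitrogen. Within the data shown here, no measured pair isolates this change. Compound 1 also carries 5-bromopyridin-2-yl, and in this assay compound 1 gives 4300 nM. On the strength of that single value, compound 3 is expected to be a stronger inhibitor than the limit reached by compound 2, by a moderate margin. The expected change is an at least 2.2-fold lower number from compound 2 to compound 3 (0.35 log units; beyond the scatter), towards a lower number. For compound 3 the estimated value is 5000 nM, with an expected range of 2000 nM to 12000 nM.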

Compound 3, half-maximal inhibitory concentration: 8000 nM
Compound 3: middle estimate off by 1.6-fold (0.20 log units), on the low side, and the stated range covers the measured number.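

Compound 2 has only a limit in this assay, not a number: the limit of >= 11300 nM in this assay, at which 1 of the 3 values shown sits.

Among these compounds, the pair formed by adding 5-bromopyridin-2-yl in place of hydrogen on the amine nitrogen isolates this change for the first time and gives an at least 1.4-fold lower number from compound 2 to compound 3 (0.14 log units; that floor lies within the scatter), so the change can be read only as a floor and its true size stays undetermined. With 5-bromopyridin-2-yl held constant, methyl in place of hydrogen on an oxygen on an aromatic ring gives a 1.9-fold higher number from compound 1 to compound 3 (0.27 log units; within the scatter), so this pair shows no separation beyond the scatter in this assay for that swap.

Still open, as far as these compounds go, is whether the bromine or the ring nitrogen of 5-bromopyridin-2-yl accounts for the step, a question that an unsubstituted pyridin-2-yl or a plain phenyl on the same amine nitrogen would address. Also open, from the compounds shown here alone, is whether a longer chain on that oxygen, such as ethyl or propyl, would stay within the scatter as the methyl and hydrogen forms do.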